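Oxetan-3-yl to 3-methyloxetan-3-yl: the next step in the series

A few compounds are considered here, and "the series" means these few. Any claim that something is new, unique, unknown or untested is made for them only; others in the source may bear on it.

In a physicochemical assay for solubility, using the shake flask method, in phosphate buffer, with a stated time of 24 h, at pH 7.4 (on this read-out higher numbers stand for higher solubility and lower numbers for lower solubility), compound 1 `CC(Sc1nc2nn(CC3COC3)cc2c(=O)n1-c1ccccc1)c1ccccc1` gives 77000 nM and compound 2 `CC(Sc1nc2nn(C3COC3)cc2c(=O)n1-c1ccccc1)c1ccccc1` gives 26000 nM, the lower of the two numbers. Compound 3 `CC(Sc1nc2nn(C3(C)COC3)cc2c(=O)n1-c1ccccc1)c1ccccc1` has methyl in place of hydrogen on a saturated ring carbon, oxetan-3-yl to 3-methyloxetan-3-yl: methyl in place of hydrogen on a saturated ring carbon. For the measured compounds named here, one measured step bears on this: a 3.0-fold lower number from compound 1 to compound 2 (0.47 log units; beyond the scatter), modest and beyond the scatter, with oxetan-3-yl in place of (oxetan-3-yl)methyl. It involves a different change, so it offers only loose guidance. A small upward move in this assay, probably within the scatter, is expected. The expected step is a 1.5-fold higher number from compound 2 to compound 3 (0.16 log units; within the scatter). The estimate for compound 3 is 38000 nM, with an expected range of 15000 nM to 90000 nM.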

Compound 3, solubility: 19000 nM
Estimate against measurement, compound 3: 2.0-fold (0.30 log units) above; the measured number falls inside the stated range.
By their numbers in this assay, from the lowest: compounds 3 and 2 (each within the scatter of the next); then compound 1.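

In this assay, methyl in place of hydrogen on the saturated ring carbon gives a 1.4-fold lower number from compound 2 to compound 3 (0.14 log units; within the scatter), so this change does not separate the two compounds beyond the scatter. The step of a 4.1-fold lower number from compound 1 to compound 3 (0.61 log units; beyond the scatter) places 3-methyloxetan-3-yl, like oxetan-3-yl, beyond the scatter from (oxetan-3-yl)methyl on the aromatic nitrogen. Nothing available accounts for either step.

Still open, on these data alone, is how an amine or a carboxylic acid on that saturated ring carbon would read in place of methyl. As far as these compounds go, a longer chain, such as ethyl, at the same place is also open.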